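Replacing Piperidinyl by an Ethyl(4-fluorobenzyl)amino Group

This account rests on a few compounds, and the source may have more. Where it says the series, first, only, none or still open, it means among the compounds named here.

Measured compounds:
Compound 1, `CCN(Cc1ccc(Br)cc1)c1ccc(C(=O)N2CCc3ccc(OS(N)(=O)=O)cc3C2)cc1`, gives 95.9%.
Compound 2, `NS(=O)(=O)Oc1ccc2c(c1)CN(C(=O)c1ccc(N3CCCCC3)cc1)CC2`, gives 38.3%.

In an assay on HEK293 cells for inhibition of Steryl-sulfatase (Homo sapiens), tested at 1 uM (on this read-out higher numbers stand for a stronger effect at the one concentration tested and lower numbers for a weaker effect), compound 2 stands lowest of the two measured compounds; the nearest number is that of compound 1, which lies well beyond the scatter above it. Compound 3, `CCN(Cc1ccc(F)cc1)c1ccc(C(=O)N2CCc3ccc(OS(N)(=O)=O)cc3C2)cc1`, has not yet been measured. It differs from compound 2 in one place: ethyl(4-fluorobenzyl)amino in place of piperidin-1-yl on an aromatic carbon. Among the measured compounds shown here, the only measured step that bears on this change is a number 57.6 percentage points lower from compound 1 to compound 2 (beyond the scatter), in which the same kind of group left the same position on the shared core and inhibition fell by a large amount. The step to compound 3 reverses that exchange, with a fluorine in place of the bromine of compound 1. A large rise in this assay is therefore expected, a number 49.7 percentage points higher from compound 2 to compound 3 (beyond the scatter). For compound 3 the estimated inhibition is 88%, with a range from 65% to 99%.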

Compound 3, a percentage reported as inhibition, at one concentration (the size of the read-out at that concentration, not a potency): 91.2%
Beside the measured number, compound 3's estimate is 3.2 percentage points below it; the measured number falls inside the stated range.
By their numbers in this assay, from the lowest: compound 2; then compounds 3 and 1 (each within the scatter of the next).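

In this assay, ethyl(4-fluorobenzyl)amino in place of piperidin-1-yl on this aromatic carbon gives a number 52.9 percentage points higher from compound 2 to compound 3 (beyond the scatter), so the high inhibition seen earlier with the bromine-bearing group does not depend on bromine. Fluoro in place of bromo gives a number 4.7 percentage points lower from compound 1 to compound 3 (within the scatter), which means that these two halogens cannot be told apart in this assay at the single concentration tested. Nothing shown here explains why the larger amino group outperforms piperidin-1-yl.

The compounds shown leave open whether any halogen is needed at all, since a plain benzyl group or one carrying a methoxy group would be needed to test that. They also leave open which part of the group matters, for example whether a propyl chain could replace the ethyl group.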